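Thiophen-2-yl in place of iodo on a fused nucleoside core

The compounds below may be only part of what the source reports. "The series", "measured", "known", "first", "only" and "open" are said of these compounds alone.

The account follows two compounds that share a nucleoside core and one that is not yet measured. Compound 1 `COc1ncnc2c1c(I)cn2[C@@H]1O[C@H](CO)[C@@H](O)[C@H]1O` stands as the only numeric result in a functional assay on K562 cells (Homo sapiens), read by MTT assay, with a stated time of 72 h (on this read-out lower numbers stand for stronger inhibition and higher numbers for weaker inhibition), where compound 1 gives 14800 nM. Compound 2 `Nc1nc2c(c(-c3ccccc3)cn2[C@@H]2O[C@H](CO)[C@@H](O)[C@H]2O)c(=O)[nH]1` reaches only the limit of this assay, at which compound 2 gives > 20000 nM; this is a limit of the assay and not a number (the limit of > 20000 nM in this assay, at which 1 of the 2 values shown sits). Among the compounds with values here, no step between two measured compounds is available here, as the two differ in more than one place. Compound 3 `COc1ncnc2c1c(-c1cccs1)cn2[C@@H]1O[C@H](CO)[C@@H](O)[C@H]1O` differs from compound 1 in one place: thiophen-2-yl in place of iodo on an aromatic carbon. For compound 3 a step of a 3.0-fold lower number from compound 1 to compound 3 (0.47 log units; beyond the scatter) toward stronger inhibition is expected, of a size somewhat beyond the scatter, though with little to anchor it. Compound 3 is therefore estimated at 5000 nM in this assay, between 1000 nM and 20000 nM.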

Compound 3, half-maximal inhibitory concentration: 6200 nM
The estimate for compound 3 lay 1.2-fold (0.09 log units) below the measured number, within the range that was stated.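

Within the data shown here, replacing iodo with thiophen-2-yl gives, in this assay, a 2.4-fold lower number from compound 1 to compound 3 (0.38 log units; beyond the scatter), and this is the first step read between two compounds that differ in one place. It shows that this aromatic carbon of the five-membered ring can carry a whole aromatic ring instead of a single iodine with no loss of inhibition, and with a modest gain. Nothing measured on either group bears on why the step runs this way.

Going by these compounds, whether this gain belongs to thiophen-2-yl itself, or whether an amine, a carboxylic acid or a longer chain such as propyl on this carbon would read the same, stays open. The value of compound 2, > 20000 nM, is a limit of the assay and not a number, and that compound differs from the others in more than one place.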